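A few compounds are considered here, and "the series" means these few. Any claim that something is new, unique, unknown or untested is made for them only; others in the source may bear on it.

Of the compounds shown here, three sharing one core have been tested in a functional assay on the whole organism for inhibition, with Rattus norvegicus as the target, read by paw edema, at a dose of 100 mg/kg by the oral route; on this read-out lower numbers stand for less inhibition and higher numbers for more inhibition at the one dose given (going by the name of the read-out). Compound 1 `O=C(NCc1ccccc1)c1c(O)c2cccnc2n(-c2ccccc2)c1=O` gives 1.6%, compound 2 `O=C(NN1CCOCC1)c1c(O)c2cccnc2n(-c2ccccc2)c1=O` gives -8.5%, and compound 3 `O=C(Nc1ccc([N+](=O)[O-])cc1)c1c(O)c2cccnc2n(-c2ccccc2)c1=O` gives -7.6%. Compound 3 thus stands second of three, yet both its neighbours sit within the scatter of it, so no order among them can be claimed. The step of a number 9.2 percentage points lower from compound 1 to compound 3 (within the scatter) is the one that bears directly on compound 4 `O=C(NCc1cccnc1)c1c(O)c2cccnc2n(-c2ccccc2)c1=O`: it exchanges a benzyl for the group that compound 4 now loses. The change (pyridin-3-yl)methyl in place of 4-nitrophenyl on an amide-type nitrogen brings in a group resembling benzyl again. The step of a number 10.1 percentage points lower from compound 1 to compound 2 (beyond the scatter) shows the only shift beyond the scatter in this small set. For compound 4 the expected step is a number 7.6 percentage points higher from compound 3 to compound 4 (within the scatter), no change beyond the scatter, giving an estimate of 0% with a range from -12% to 12%.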

Compound 4, a percentage reported as inhibition, in the whole organism at one dose (the size of the read-out at that dose, not a potency): 25.5%
For compound 4 the middle estimate is 25.5 percentage points below the measured one; measured number above the stated range.
By their numbers in this assay, from the lowest: compounds 2, 3 and 1 (each within the scatter of the next, the first and the last beyond it); then compound 4.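

In this assay, the amide-type nitrogen proved able to carry a clear gain, which none of the earlier groups showed: a number 33.1 percentage points higher from compound 3 to compound 4 (beyond the scatter) and a number 34 percentage points higher from compound 2 to compound 4 (beyond the scatter) are both large. The tightest comparison is a number 23.9 percentage points higher from compound 1 to compound 4 (beyond the scatter), since only phenyl gives way to pyridin-3-yl on the same saturated chain carbon, so the gain depends on the ring and not on the chain alone. No available measurement explains this gain.

Still open, going by these compounds, is whether the ring nitrogen's place matters, as a (pyridin-2-yl)methyl or (pyridin-4-yl)methyl group would show. Also open, on these data alone, is how a longer chain between the amide-type nitrogen and the pyridine ring would read out.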